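A few compounds are considered here, and "the series" means these few. Any claim that something is new, unique, unknown or untested is made for them only; others in the source may bear on it.

In a functional assay on HeLa cells (Homo sapiens) for antiproliferative activity, read by MTT assay, with a stated time of 48 h (on this read-out higher numbers stand for weaker inhibition of growth and lower numbers for stronger inhibition of growth), the measured compounds are these.
Compound 1, `COc1ccc(/C=C2\Cc3c(cc(OC)c(OC)c3OC)C2=O)cc1`, gives 485 nM.
Compound 2, `COc1ccc(/C=C2\Cc3c(cc(OC)c(OC)c3OC)C2=O)cc1N`, gives 169 nM.
Compound 3, `COc1ccc(/C=C2\Cc3cc(OC)c(OC)c(OC)c3C2=O)cc1`, is known only as a limit of the assay, > 10000 nM.

Compound 1 and compound 2 share one core and differ in a single change, (amino in place of hydrogen on an aromatic carbon). That change produced a 2.9-fold lower number from compound 1 to compound 2 (0.46 log units; beyond the scatter). Compound 3 has the same atoms as compound 1 joined differently; the difference between the two cores is not broken down here. Compound 4, `COc1ccc(/C=C2\Cc3cc(OC)c(OC)c(OC)c3C2=O)cc1N`, has not yet been measured in this assay. It carries the same change relative to compound 3, (amino in place of hydrogen on an aromatic carbon), with the place described in the same words. Resting on the step of a 2.9-fold lower number from compound 1 to compound 2 (0.46 log units; beyond the scatter), compound 4 is expected to show an at least 1.6-fold lower number from compound 3 to compound 4 (0.22 log units; that floor lies within the scatter). Because compound 3 sits at the limit (the limit of > 10000 nM in this assay, at which 1 of the 3 values shown sits), the result for compound 4 may again be only a limit. The estimate for compound 4 is 6000 nM, expected to lie between 2000 nM and 30000 nM.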

Compound 4, concentration for 50% growth inhibition: > 10000 nM
Compound 4 gave a limit, no number; the forecaster's own chance of this, stated with the estimate: 50%; at least 1.6-fold (0.22 log units) between middle value and limit.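

No step can be read from compound 3 to compound 4, because both stand only as a limit: the limit of > 10000 nM in this assay, at which 2 of the 4 values shown sit. On these data alone, whether amino changes growth inhibition on the core of compound 3, as it did from compound 1 to compound 2, stays open.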